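The source may hold more compounds than are shown below. What is called first, only, known or untested is meant among the compounds shown, and "the series" means these compounds.

Compound 1, `CC[C@H](C)[C@H](N)CN(C(=O)[C@@H]1C[C@H]1c1ccc(Cl)cc1)c1ccc(-c2ccccc2)cc1`: 4300 nM
Compound 2, `CC[C@H](C)[C@H](N)CN(C(=O)[C@@H]1C[C@H]1c1cccc(Cl)c1)c1ccc(-c2ccccc2)cc1`: 2200 nM
Compound 3, `CC[C@H](C)[C@H](N)CN(C(=O)[C@@H]1C[C@H]1c1ccc(F)c(F)c1)c1ccc(-c2ccccc2)cc1`: 720 nM

These three compounds share one core and differ only in the aromatic group on a saturated ring carbon; all were tested in a functional assay for agonist activity at G protein-coupled receptor 88 (Homo sapiens), read by HTRF and cAMP accumulation; a higher number here means that more compound is needed for the effect, a lower number that less compound is needed. Compound 3 stands at the lowest number of the three. Its separation from compound 2 is a 3.1-fold lower number from compound 2 to compound 3 (0.49 log units; beyond the scatter), and from compound 1 it is a 6.0-fold lower number from compound 1 to compound 3 (0.78 log units; beyond the scatter), both beyond the scatter, whereas the step of a 2.0-fold lower number from compound 1 to compound 2 (0.29 log units; within the scatter) is within it. So this one position is where the numbers have moved so far.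

Compound 4, `CC[C@H](C)[C@H](N)CN(C(=O)[C@@H]1C[C@H]1c1ccccn1)c1ccc(-c2ccccc2)cc1`, changes the same position again: pyridin-2-yl in place of 3,4-difluorophenyl on a saturated ring carbon. The measured steps bear on it only in part. They show that exchanging halogen patterns on a carbon-only ring shifts the number modestly, but none of them replaces that ring with one carrying a hetero atom, so the direction of this new change is not shown directly. A step toward a higher number beyond the scatter is expected, because the step of a 6.0-fold lower number from compound 1 to compound 3 (0.78 log units; beyond the scatter) shows that the fluorine pattern of compound 3 sets it apart from its nearest analogues. Compound 4 is therefore estimated at 2500 nM, with a range from 700 nM to 9000 nM. The expected step this estimate means is a 3.5-fold higher number from compound 3 to compound 4 (0.54 log units; beyond the scatter).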

Compound 4, half-maximal effective concentration: 130 nM
Beside the measured number, compound 4's estimate is 19-fold (1.28 log units) above it; the measured number lies below the stated range.
By their numbers in this assay, from the lowest: compound 4; then compound 3; then compounds 2 and 1 (each within the scatter of the next).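

Until now, only halogen patterns on a carbon-only aromatic ring had been compared on this cyclopropyl carbon. In this assay, pyridin-2-yl, a ring with 1 hetero atom and 1 hydrogen-bond acceptor, gives a lower number than the best of those rings (a 5.5-fold lower number from compound 3 to compound 4 (0.74 log units; beyond the scatter)), so within these four compounds a halogen is not needed for the lowest number, and the ring itself can be exchanged with a clear gain. The steps from the chlorine-bearing rings are larger still (a 17-fold lower number from compound 2 to compound 4 (1.23 log units; beyond the scatter); a 33-fold lower number from compound 1 to compound 4 (1.52 log units; beyond the scatter)), and both exceed any step among the halogen-bearing rings, yet no measurement shown here explains why the pyridin-2-yl compound needs less compound for the effect.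

The compounds shown leave open whether the ring nitrogen itself matters, since plain phenyl, with no halogen at all, would be the direct comparison for compound 4. They also leave open whether the nitrogen's place in the ring counts, which pyridin-3-yl and pyridin-4-yl would test, and whether a five-membered ring such as thiazol-2-yl would serve as well.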